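The source may hold more compounds than are shown below. What is called first, only, known or untested is meant among the compounds shown, and "the series" means these compounds.

Compound 1 `Cc1nc2ccc(C#CC(C)(C)O)cc2n1-c1ncnc(N)n1`: 15300 nM
Compound 2 `Cc1nc2ccc(C#CC(C)(O)CO)cc2n1-c1ncnc(N)n1`: > 4500 nM
Compound 3 `Cc1nc2ccc(C#CC(C)(O)CC3CC3)cc2n1-c1ncnc(N)n1`: > 4500 nM

In an assay for binding affinity to serine/threonine-protein kinase PAK 1 (Homo sapiens), read by FRET and Z'-LYTE, with stated times of 10 min and 60 min (a higher number here means a weaker inhibitor, a lower number a stronger inhibitor), compound 1 gives 15300 nM. Compound 2 reaches only the limit of > 4500 nM. Compound 3 likewise reaches only the limit of > 4500 nM, so its place among the measured compounds is known only as that limit. The steps a step that the limit leaves unreadable from compound 1 to compound 2, a step that the limit leaves unreadable from compound 1 to compound 3 and a step that the two limits leave unreadable from compound 2 to compound 3 all remain unreadable because of the limit of > 4500 nM in this assay, at which 2 of the 3 values shown sit.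

Compound 4 `Cc1nc2ccc(C#CC3(O)CCCOC3)cc2n1-c1ncnc(N)n1` differs from compound 3 by a group of 7 heavy atoms (5 carbon, 2 oxygen; one six-membered non-aromatic ring with 1 hetero atom) in place of a group of 7 heavy atoms (6 carbon, 1 oxygen; one three-membered non-aromatic ring of carbon only), on a triple-bonded carbon. No readable step bears on this change, so no direction beyond the scatter can be expected. Compound 4 is therefore expected to stay near where compound 3 stands, a step that the limit leaves unreadable from compound 3 to compound 4 in this assay. Compound 4 is estimated at 9000 nM, between 3000 nM and 30000 nM.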

Compound 4, inhibition constant: > 4500 nM
Compound 4: a limit, no number; the forecaster's own chance of this, stated with the estimate: 55%; the middle value is on the limit's open side.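

Compound 4 also gives only a limit, so its steps from compound 1, compound 2 and compound 3 cannot be read: the limit of > 4500 nM in this assay, at which 3 of the 4 values shown sit. The compounds shown leave open how strongly compound 2, compound 3 and compound 4 actually inhibit, and whether changing the group on the triple-bonded carbon alters that.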